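Furan-2-yl in Place of 4-Chlorophenyl on the Carbonyl

A few compounds are considered here, and "the series" means these few. Any claim that something is new, unique, unknown or untested is made for them only; others in the source may bear on it.

Measured compounds:
Compound 1 `CC1=CC[C@H]2[C@H](CC[C@]2(C)O)C(C)(C)[C@@H]1CC[C@H]1[C@]2(C)CC[C@H](OC(=O)c3ccc(Cl)cc3)C(C)(C)O[C@H]2CC[C@@]1(C)O`, which in a functional assay on MDA-MB-231 cells (Homo sapiens) for antiproliferative activity, read by MTT assay, with a stated time of 72 h (a higher number here means a weaker inhibitor, a lower number a stronger inhibitor), gives 10300 nM.
Compound 2 `CC1=CC[C@H]2[C@@H]1CC=C(C)[C@@H](CC[C@H]1[C@]3(C)CC[C@H](OC(=O)c4ccncc4)C(C)(C)O[C@H]3CC[C@@]1(C)O)C2(C)C`, which in this assay gives 19100 nM.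

Of the two numbers, compound 1 has the lower one, and compound 2 is its nearest neighbour; the two values lie within the usual scatter of each other, so nothing separates them. For the measured compounds named here, no step between measured compounds that differ in one place is available, so no measured step of this kind guides the next move.

Compound 3 `CC1=CC[C@H]2[C@H](CC[C@]2(C)O)C(C)(C)[C@@H]1CC[C@H]1[C@]2(C)CC[C@H](OC(=O)c3ccco3)C(C)(C)O[C@H]2CC[C@@]1(C)O` keeps the core of compound 1 and differs from it in one place: furan-2-yl in place of 4-chlorophenyl on a carbonyl carbon. The group on the carbonyl carbon changes from a six-membered aromatic ring of carbon only to a five-membered aromatic ring with one hetero atom, and the part that enters carries one hydrogen-bond acceptor where the part that leaves carries none. Going by the values given here, with no measured step of this kind, the step of a 1.3-fold higher number from compound 1 to compound 3 (0.10 log units; within the scatter) is expected to be small, a modest shift upward at most, and it could equally fall within the scatter. Compound 3 is therefore expected to give 13000 nM in this assay, with a range from 5000 nM to 35000 nM.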

Compound 3, half-maximal inhibitory concentration: 14000 nM
Beside the measured number, compound 3's estimate is 1.1-fold (0.03 log units) below it; low and high end bracket the measured number.
By their numbers in this assay, from the lowest: compounds 1, 3 and 2 (each within the scatter of the next).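

Furan-2-yl in place of 4-chlorophenyl on the carbonyl carbon gives a 1.4-fold higher number from compound 1 to compound 3 (0.13 log units; within the scatter) in this assay, so the first measured exchange at this position does not separate the two compounds. The exchange replaces a six-membered aromatic ring of carbon only with a five-membered aromatic ring with one hetero atom, removes the chlorine and brings in a hydrogen-bond acceptor, and the read-out registers no difference beyond the scatter, which shows that this particular pair of aromatic groups can be exchanged on the core of compound 1 without a measurable separation. No independent measurement bears on why the two compounds read alike.

The compounds shown leave open what a group of a different kind on this carbonyl carbon would do, such as a straight alkyl chain, an aminomethyl group or a phenyl ring carrying a carboxylic acid. They also leave open how plain phenyl would read, a group that would take the chlorine away while keeping the six-membered ring of carbon only.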